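The compounds below may be only part of what the source reports. "The series", "measured", "known", "first", "only" and "open" are said of these compounds alone.

Compounds in this small series share one core and differ in the aromatic ring on a carbon with a double bond to nitrogen. Their antiproliferative activity was measured in a functional assay on MCF7 cells (Homo sapiens) for antiproliferative activity, read by MTT assay, with a stated time of 72 h; on this read-out higher numbers stand for weaker inhibition and lower numbers for stronger inhibition. In this assay, among the compounds with values here, compound 1 `O=C(N/N=C/c1ccc(Br)cc1)Nc1ccc(Oc2ccnc3[nH]ccc23)c(F)c1` gives 930 nM, the only actual number in the set. Compound 2 `O=C(N/N=C/c1cccc([N+](=O)[O-])c1)Nc1ccc(Oc2ccnc3[nH]ccc23)c(F)c1` is reported as "not active" (no number reported), so it has no single number and no exact place on the scale. Compound 3 `O=C(N/N=C/c1cccc(Cl)c1Cl)Nc1ccc(Oc2ccnc3[nH]ccc23)c(F)c1` is also reported as "not active" (no number reported).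

Compound 4 `O=C(N/N=C/c1ccc(F)cc1Cl)Nc1ccc(Oc2ccnc3[nH]ccc23)c(F)c1`, not yet measured, differs from compound 2 in one place: 2-chloro-4-fluorophenyl in place of 3-nitrophenyl on a carbon with a double bond to nitrogen. In words, it has 2-chloro-4-fluorophenyl in place of 3-nitrophenyl on a carbon with a double bond to nitrogen.

Without a number for compound 2, the size of this step cannot be calculated. The expected direction is from no reported activity towards measurable inhibition in this assay, although this is far from certain. Compound 1, which carries bromine on this ring, gives 930 nM, while compound 3, which carries chlorine there, is reported as "not active" (no number reported). Halogen alone therefore does not settle the outcome, and compound 4 could also prove inactive. If a number is obtained, the expected half-maximal inhibitory concentration of compound 4 is 1500 nM, within an estimated range of 400 nM to 6000 nM.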

Compound 4, half-maximal inhibitory concentration: 7610 nM
The estimate for compound 4 lay 5.1-fold (0.71 log units) below the measured number; the whole stated range lies below it.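

In this assay, the 2-chloro-4-fluorophenyl ring on a carbon with a double bond to nitrogen gives a real number, so this place can hold a ring with two halogen atoms and keep measurable activity, whereas compound 3, whose ring also carries two halogen atoms, is reported as not active; the step from compound 2 cannot be read, as compound 2 has no number. Within the data shown here, replacing 4-bromophenyl with 2-chloro-4-fluorophenyl gives an 8.2-fold higher number from compound 1 to compound 4 (0.91 log units; beyond the scatter), a modest loss that keeps the single bromine ring of compound 1 as the one with the lowest number so far, and shows that which halogens the ring carries, and how many, can change the result. Nothing measured here explains these differences between the rings.

The compounds shown leave open whether the chlorine or the fluorine of compound 4 drives the step, as no ring here carries only one of those two atoms. They also leave open how this place would respond to a ring bearing a methoxy group, an amine or a carboxylic acid.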